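A few compounds are considered here, and "the series" means these few. Any claim that something is new, unique, unknown or untested is made for them only; others in the source may bear on it.

In a functional assay on MV4-11 cells (Homo sapiens) for inhibition, read by resazurin assay, with a stated time of 72 h (a lower number here means a stronger inhibitor of growth, a higher number a weaker inhibitor of growth), compound 2 `CCCCOc1nc(C)c(-c2ccnc(Nc3ccc(OC)cc3OC)n2)s1` gives 7860 nM and compound 1 `COc1ccc(Nc2nccc(-c3sc(SC(C)C)nc3C)n2)c(OC)c1` gives 5670 nM. For the measured compounds named here, these two numbers lie within the usual scatter of each other, so compound 2 cannot be told apart from the only other compound measured so far. Compound 3 `CCOc1nc(C)c(-c2ccnc(Nc3ccc(OC)cc3OC)n2)s1` keeps the core of compound 2 but has ethoxy in place of butoxy: hydrogen in place of ethyl on a saturated chain carbon, two bonds along the chain from an oxygen on an aromatic ring. Going by the values given here, no measured step makes this exact change. Among the compounds with values here, the closest evidence is the one step available, a 1.4-fold higher number from compound 1 to compound 2 (0.14 log units; within the scatter), which swaps isopropylsulfanyl for butoxy and stays within the scatter. Within the data shown here, with only that modest guide, no change beyond the scatter is expected in this assay. The estimated step, a 1.2-fold lower number from compound 2 to compound 3 (0.08 log units; within the scatter), is accordingly expected to be small. For compound 3 the estimated value is 6500 nM, with an expected range from 2500 nM to 16000 nM.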

Compound 3, concentration for 50% growth inhibition: 3890 nM
Beside the measured number, compound 3's estimate is 1.7-fold (0.22 log units) above it, within the range that was stated.
By their numbers in this assay, from the lowest: compounds 3, 1 and 2 (each within the scatter of the next, the first and the last beyond it).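

In this assay, going from butoxy to ethoxy gives a 2.0-fold lower number from compound 2 to compound 3 (0.31 log units; beyond the scatter) and is the only step among these compounds that lies beyond the scatter, though only modestly. This shows that trimming the chain on this oxygen by an ethyl unit can shift the number, which the earlier comparison of butoxy with isopropylsulfanyl could not show. Ethoxy set against isopropylsulfanyl gives a 1.5-fold lower number from compound 1 to compound 3 (0.16 log units; within the scatter), so these two groups cannot be told apart here, and nothing available explains the effect of the shorter chain.

A single step between two chain lengths does not establish a trend with chain length. From the compounds shown here alone, whether methoxy, a longer chain such as hexyloxy, or an amine on the same aromatic carbon would lower or raise the number remains open.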